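Fluoro to iodo on compound 3

The compounds below may be only part of what the source reports. "The series", "measured", "known", "first", "only" and "open" are said of these compounds alone.

Compound 1 `CC(C)(C)NC(=O)CCc1cccc2c1B(O)OC2`: > 100000 nM, a limit of the assay rather than a number.
Compound 2 `O=C(CCc1cccc2c1B(O)OC2)Nc1ccccc1`: 200 nM
Compound 3 `O=C(CCc1cccc2c1B(O)OC2)Nc1ccc(F)cc1`: 720 nM

In a functional assay on SK-OV-3 cells (Homo sapiens) for antiproliferative activity, read by MTT assay, with a stated time of 72 h (on this read-out lower numbers stand for stronger inhibition and higher numbers for weaker inhibition), compound 3 holds the higher of the two exact numbers, 720 nM. The gap to its nearest neighbour is a 3.6-fold higher number from compound 2 to compound 3 (0.56 log units; beyond the scatter). Compound 4 `O=C(CCc1cccc2c1B(O)OC2)Nc1ccc(I)cc1` carries one change: iodo in place of fluoro on an aromatic carbon, para to a large group. Among the measured compounds shown here, the only measured change on this carbon is fluoro in place of hydrogen, a modest step. The much larger an at least 130-fold lower number from compound 1 to compound 3 (2.14 log units; beyond the scatter) concerns the group on an amide-type nitrogen instead. Going by the modest 3.6-fold higher number from compound 2 to compound 3 (0.56 log units; beyond the scatter), a small or modest step of uncertain direction is expected in this assay, possibly none beyond the scatter. The expected change is a 1.1-fold lower number from compound 3 to compound 4 (0.04 log units; within the scatter). For compound 4 the estimate is 650 nM, with an expected range of 180 nM to 2500 nM.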

Compound 4, half-maximal inhibitory concentration: 51000 nM
Compound 4: middle estimate off by 78-fold (1.89 log units), on the low side; the measured number lies above the stated range.
By their numbers in this assay, from the lowest: compound 2; then compound 3; then compound 4. At a limit, above all of these: compound 1.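

Iodo on the carbon para to a large group is far from a neutral swap for fluoro: the change gives a 71-fold higher number from compound 3 to compound 4 (1.85 log units; beyond the scatter), and the comparison with the plain phenyl gives a 260-fold higher number from compound 2 to compound 4 (2.41 log units; beyond the scatter). The tert-butyl comparison reads an at least 1.9-fold lower number from compound 1 to compound 4 (0.29 log units; that floor lies within the scatter), so iodo erases most of what the aromatic ring gained. Compound 1 stands at a limit of the assay, not a number: the limit of > 100000 nM in this assay, at which 1 of the 4 values shown sits.

As far as these compounds go, whether chloro or bromo on this carbon would fall between fluoro and iodo remains open. So does how an amine or a carboxylic acid would fare there.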